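From Carboxy to Methylcarbamoyl: Expected Oral Exposure

A few compounds are considered here, and "the series" means these few. Any claim that something is new, unique, unknown or untested is made for them only; others in the source may bear on it.

Three compounds have been measured in an ADME assay on the whole organism (Macaca fascicularis) for pharmacokinetics, read by LC-MS, using cassette dosing, at a dose of 1 mg/kg by the oral route; on this read-out higher numbers stand for higher exposure at the dose given and lower numbers for lower exposure:

compound 1, `CCCCN(c1nc2ccccc2o1)[C@H](C)c1ccc(-c2ccccc2-c2nnn[nH]2)cc1`, gives 44.3 ng.h/mL
compound 2, `CCCCN(c1nc2c(C(=O)O)cccc2o1)[C@H](C)c1ccc(-c2ccccc2-c2nnn[nH]2)cc1`, gives 429 ng.h/mL
compound 3, `C[C@H](c1ccc(-c2ccccc2-c2nc(=O)o[nH]2)cc1)N(CC1CC1)c1nc2c(C(=O)O)cccc2o1`, gives 11600 ng.h/mL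

Compound 2 stands second highest of the three numbers. Its nearest neighbour is compound 1, and the step of a 9.7-fold higher number from compound 1 to compound 2 (0.99 log units; beyond the scatter) lies beyond the scatter. Within the data shown here, compound 3 stands furthest away with a higher number; no single-point step connects it to compound 2, so only the two values themselves can be compared.

Compound 4, `CCCCN(c1nc2c(C(=O)NC)cccc2o1)[C@H](C)c1ccc(-c2ccccc2-c2nnn[nH]2)cc1`, has not yet been measured in this assay. It differs from compound 2 in one place: methylamino in place of hydroxy on a carbonyl carbon. Among the measured compounds shown here, the only measured step that touches this part of the molecule is the one from compound 1 to compound 2, in which the carboxy group entered and gave a 9.7-fold higher number from compound 1 to compound 2 (0.99 log units; beyond the scatter). Going by these compounds, nothing measured shows what follows when the hydroxy of that carboxy is exchanged for methylamino, so the direction of the step remains open. The estimate for compound 4 is therefore placed close to compound 2, with a wide range, and the step of a 1.7-fold lower number from compound 2 to compound 4 (0.23 log units; within the scatter) is expected to stay within the scatter. Compound 4 is thus expected to give about 250 ng.h/mL in this assay, between 50 ng.h/mL and 1300 ng.h/mL.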

Compound 4, area under the concentration-time curve: 25.7 ng.h/mL
The estimate for compound 4 lay 9.7-fold (0.99 log units) above the measured number; measured number below the stated range.
By their numbers in this assay, from the lowest: compounds 4 and 1 (each within the scatter of the next); then compound 2; then compound 3.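

In this assay, the higher number that came with the carboxy group on this aromatic carbon does not extend to every carbonyl group placed there: exchanging the hydroxy for methylamino on the carbonyl carbon gives a 17-fold lower number from compound 2 to compound 4 (1.22 log units; beyond the scatter) and so removes far more than the usual scatter could account for. Methylcarbamoyl in place of hydrogen on the same aromatic carbon gives a 1.7-fold lower number from compound 1 to compound 4 (0.24 log units; within the scatter) and thus leaves the number within the scatter, so the carbonyl carbon alone does not carry the higher exposure seen with carboxy, and what is attached to it decides the outcome in this pair of compounds. No measurement offered here bears on why carboxy and methylcarbamoyl part so sharply at this position.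

Going by these compounds, it remains open whether a primary carboxamide, a dimethylcarbamoyl group or a methyl ester on this aromatic carbon would stand with carboxy or with methylcarbamoyl. On these data alone, it is equally open whether methylamino in place of hydroxy would have a similar effect on the number of compound 3, whose other parts differ from those of compound 2.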